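Long Chain Replaces Phenyl in a Bis-Carbamate Series

The source may report more compounds than this note shows. Statements on the series, on what has been measured and on what is new or still open speak of the compounds shown alone.

Compound 1 `CCCCCCCCCCCCCCN(C)C(=O)NC(=O)Nc1c(C(C)C)cccc1C(C)C`: 1700 nM
Compound 2 `CC(C)c1cccc(C(C)C)c1OC(=O)NC(=O)OCCCc1ccccc1`: 660 nM

Of the compounds shown here, two have been measured in an assay on microsomes from intestine for inhibition of acyl-CoA:cholesterol acyltransferase (Oryctolagus cuniculus); on this read-out higher numbers stand for weaker inhibition and lower numbers for stronger inhibition. Compound 2 holds the lowest of the two numbers; the nearest, compound 1, gives 1700 nM, a gap beyond the usual scatter. Compound 3 `CCCCCCCCCCCCCCOC(=O)NC(=O)Oc1c(C(C)C)cccc1C(C)C` has not yet been tested in this assay. It differs from compound 2 by undecyl in place of phenyl on a saturated chain carbon, three bonds along the chain from an oxygen next to a carbonyl group. Among the measured compounds shown here, no step between measured compounds is on record, so the size of this change is uncertain; compound 3 is expected to give a modest drop in the number from compound 2, estimated as a 1.7-fold lower number from compound 2 to compound 3 (0.22 log units; within the scatter). For compound 3 the expected value is 400 nM, in the range 100 nM to 2000 nM.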

Compound 3, half-maximal inhibitory concentration: 10 nM
Beside the measured number, compound 3's estimate is 40-fold (1.60 log units) above it, and the stated range ends above it.
By their numbers in this assay, from the lowest: compound 3; then compound 2; then compound 1.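

In this assay, undecyl in place of phenyl on a saturated chain carbon gives a 66-fold lower number from compound 2 to compound 3 (1.82 log units; beyond the scatter) and so marks this position as highly sensitive to the group it carries. The step goes well beyond the usual scatter, and it shows that a chain with no ring is tolerated here and gives the stronger inhibition of the pair. Nothing on hand accounts for the size of this step. The compounds shown do not separate the gain in chain length from the loss of the phenyl ring. From the compounds shown here alone, it also remains open whether a longer chain, or an amine at the chain end, would keep this inhibition.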